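The source may hold more compounds than are shown below. What is called first, only, known or untested is meant among the compounds shown, and "the series" means these compounds.

Of the compounds shown here, three built on one shared core have so far been tested in a functional assay on SF-268 cells (Homo sapiens) for cytotoxicity, read by sulforhodamine B assay, with a stated time of 48 h, tested at 10 uM; a lower number here means a stronger effect, a higher number a weaker effect of the compound at the concentration tested. Compound 1 `COc1cc(-c2cc(/C=C/C(=O)c3ccc(Cl)c(Cl)c3)[nH]n2)cc(OC)c1OC` gives 60%, the highest of the three numbers. Compound 2 `COc1ccc(-c2cc(/C=C/C(=O)c3cc(OC)c(OC)c(OC)c3)[nH]n2)cc1OC` gives -56%, and compound 3 `COc1cc(C(=O)/C=C/c2cc(-c3cc(OC)c(OC)c(OC)c3)n[nH]2)cc(OC)c1OC` gives -45%; both lie far below compound 1, beyond the scatter, so compound 1 shows the weakest effect of the three at the concentration used. Among the measured compounds shown here, the only single-point change measured so far is the step of a number 11 percentage points higher from compound 2 to compound 3 (beyond the scatter), a modest one that concerns a methoxy group in place of hydrogen on an aromatic carbon.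

Compound 4 `COc1cc(-c2cc(/C=C/C(=O)c3ccc(F)c(F)c3)[nH]n2)cc(OC)c1OC` differs from compound 1 in one place: 3,4-difluorophenyl in place of 3,4-dichlorophenyl on a carbonyl carbon. For the measured compounds named here, no measured step touches an exchange of one halogen for another on the carbonyl carbon; the one step that exists says nothing about it. With only compound 1 itself as an anchor, the expected change is small and may well fall within the scatter, in either direction. The step of a number 5 percentage points higher from compound 1 to compound 4 (within the scatter) is therefore expected to stay close to zero. Compound 4 is estimated at 65%, with a range from 35% to 95%.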

Compound 4, a percentage reported as activity, at one concentration (the size of the read-out at that concentration, not a potency): 17%
Estimate against measurement, compound 4: 48 percentage points above, and the stated range ends above it.
By their numbers in this assay, from the lowest: compound 2; then compound 3; then compound 4; then compound 1.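

In this assay, among the compounds shown here, the exchange on the carbonyl carbon gives a number 43 percentage points lower from compound 1 to compound 4 (beyond the scatter) and so shows that this group is not a silent part of the shared core: the first single change measured here moves the read-out towards a stronger effect at the concentration tested, whereas the one earlier step concerned a methoxy group elsewhere in the molecule. The change is also a narrow one, as 3,4-dichlorophenyl and 3,4-difluorophenyl have the same heavy-atom count, one six-membered aromatic ring of carbon only, no hydrogen-bond donors or acceptors and no net charge, so those counts alone do not predict the result and the visible difference is the halogen carried. Nothing measured here explains why the difluorophenyl compound gives the lower number.

On these data alone, a single pair of halogens defines no trend, so it remains open whether a 3,4-dibromophenyl group, or a phenyl ring carrying an amine or a carboxylic acid, would lower the number further or raise it. As far as these compounds go, it is equally open whether the same exchange would have a similar effect on the core of compound 2, which has one methoxy group fewer.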